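Benzyloxy to Fluoro on the Benzylamide Aryl Ring

The compounds below may be only part of what the source reports. "The series", "measured", "known", "first", "only" and "open" are said of these compounds alone.

Of the compounds shown here, three sharing one core have been measured in an assay on CHO cells for antagonist activity at transient receptor potential cation channel subfamily V member 1 (Homo sapiens), read by FLIPR; a higher number here means a weaker inhibitor, a lower number a stronger inhibitor. Compound 1 `CCCCN(C)c1cc(C(F)(F)F)ccc1CNC(=O)C(C)c1ccc(NS(C)(=O)=O)c(F)c1` gives 1.2 nM. Compound 2 `CC(C)CCOc1cc(C(F)(F)F)ccc1CNC(=O)C(C)c1ccc(NS(C)(=O)=O)c(F)c1` gives 0.5 nM. Compound 3 `CC(C(=O)NCc1ccc(C(F)(F)F)cc1OCc1ccccc1)c1ccc(NS(C)(=O)=O)c(F)c1` gives 0.9 nM. Among these three numbers compound 3 stands second highest, yet every step that reaches it is small: a 1.3-fold lower number from compound 1 to compound 3 (0.12 log units; within the scatter) and a 1.8-fold higher number from compound 2 to compound 3 (0.26 log units; within the scatter) both lie within the scatter. Among the compounds with values here, the only step beyond the scatter is a 2.4-fold lower number from compound 1 to compound 2 (0.38 log units; beyond the scatter), a modest one.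

Compound 4 `CC(C(=O)NCc1ccc(C(F)(F)F)cc1F)c1ccc(NS(C)(=O)=O)c(F)c1` has not yet been measured in this assay. It differs from compound 3 as follows: fluoro in place of benzyloxy on an aromatic carbon. All three measured steps bear on this position, since each exchanges one large group for another there, and none moves the number by more than a modest amount. Within the data shown here, no measured step, however, removes the large group entirely in favour of a single fluorine; the series offers no direct precedent for that. The expectation is therefore cautious: an increase in the number is thought more likely than a decrease, of a size around a 5.6-fold higher number from compound 3 to compound 4 (0.74 log units; beyond the scatter). Compound 4 is estimated at 5 nM, with a range from 1 nM to 30 nM.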

Compound 4, inhibition constant: 68.7 nM
Estimate against measurement, compound 4: 14-fold (1.14 log units) below; the whole stated range lies below it.
By their numbers in this assay, from the lowest: compounds 2, 3 and 1 (each within the scatter of the next, the first and the last beyond it); then compound 4.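

Across compounds 1, 2 and 3, the butyl(methyl)amino, isopentyloxy and benzyloxy groups on this aromatic carbon differ by no more than a modest step in this assay, but the single fluorine brings a 76-fold higher number from compound 3 to compound 4 (1.88 log units; beyond the scatter) together with a 140-fold higher number from compound 2 to compound 4 (2.14 log units; beyond the scatter) and also a 57-fold higher number from compound 1 to compound 4 (1.76 log units; beyond the scatter) in the same direction. The position therefore accepts large groups of quite different build, while the one small group shown costs far more than any exchange among them. The step from compound 3 to compound 4 removes a carbon-only aromatic ring and a hydrogen-bond acceptor along with most of the heavy atoms, and no data presented here account for the rise in the number.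

The compounds shown leave open how much of the group on this carbon is needed, since a methoxy or ethoxy group would show whether the number climbs gradually or abruptly as the chain shortens. They also leave open whether a plain hydrogen, a hydroxy group or a small amine at this carbon would behave like the fluoro compound or like the larger groups.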